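The compounds below may be only part of what the source reports. "The series", "measured", "known", "first", "only" and "open" are said of these compounds alone.

Of the compounds shown here, two have been measured in a functional assay (aorta) with Oryctolagus cuniculus as the target; on this read-out higher numbers stand for weaker binding and lower numbers for tighter binding. Compound 1 `COc1cc(C(C)=O)ccc1OCCCCCN1CCC(C(c2ccc(F)cc2)c2ccc(F)cc2)CC1` gives 3.16 nM in this assay. Going by the values given here, compound 2 `COc1cc(C(C)O)ccc1OCCCN1CCC(C(c2ccc(F)cc2)c2ccc(F)cc2)CC1` gives 10 nM in this assay, which is the highest of the two numbers and therefore the weaker of the pair; its only neighbour is compound 1, whose number is lower by a gap beyond the usual scatter.

Compound 3 `Fc1ccc(C(c2ccc(F)cc2)C2CCN(CCCOc3ccc4ccccc4c3)CC2)cc1` has not yet been measured. It differs from compound 2 in one place: naphthalen-2-yl in place of 4-(1-hydroxyethyl)-2-methoxyphenyl on an oxygen on a saturated carbon. The group that leaves carries a hydroxyl and a methoxy on its ring, whereas the group that enters is a bare pair of fused aromatic rings.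

Among the compounds with values here, no measured pair shows what this kind of exchange does, so the direction cannot be read off the data. The step of no change at the digits printed from compound 2 to compound 3 (within the scatter) is expected to stay within the scatter. In this assay compound 3 is expected to give about 10 nM, most likely between 3 nM and 32 nM.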

Compound 3, dissociation constant: 7.94 nM
For compound 3 the middle estimate is 1.3-fold (0.10 log units) above the measured one, within the range that was stated.
By their numbers in this assay, from the lowest: compound 1; then compounds 3 and 2 (each within the scatter of the next).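

In this assay the exchange of 4-(1-hydroxyethyl)-2-methoxyphenyl for naphthalen-2-yl on this oxygen gives a 1.3-fold lower number from compound 2 to compound 3 (0.10 log units; within the scatter) and so leaves the read-out in the same range. The group that leaves carries a hydroxyl and a methoxy, while the group that enters has no hydrogen-bond donors or acceptors, so in this pair neither of those two substituents is needed for a number of this size. Nothing measured here explains this outcome.

On these data alone, whether an amine or a carboxylic acid on the ring at this place would keep the number in the same range stays open. Compound 1 differs from compound 2 in more than one place, so the separate effects of chain length and of the carbonyl in place of the hydroxyl cannot be read.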